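Swapping a Dichlorophenyl Urea End for Trifluoromethylphenyl

A few compounds are considered here, and "the series" means these few. Any claim that something is new, unique, unknown or untested is made for them only; others in the source may bear on it.

Two urea compounds built on a shared core have been tested in a functional assay on NCI/ADR-RES cells (Homo sapiens) for inhibition, read by sulforhodamine B assay, with a stated time of 48 h, tested at 0.01 uM; on this read-out higher numbers stand for a weaker effect at the one concentration tested and lower numbers for a stronger effect. Compound 1 `COc1cc(Cl)cc(-c2nn(-c3cccc(NC(=O)Nc4cc(C(F)(F)F)cc(C(F)(F)F)c4)c3)cc2-c2ccncc2)c1` gives 99% in this assay. Compound 2 `COc1cc(Cl)cc(-c2nn(-c3cccc(NC(=O)Nc4ccc(Cl)c(Cl)c4)c3)cc2-c2ccncc2)c1` gives 97% in this assay, a number that lies within the usual scatter of the value for compound 1, so the two cannot be told apart on this read-out; both show almost no effect at the single concentration used.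

The unmeasured compound 3 `COc1cc(Cl)cc(-c2nn(-c3cccc(NC(=O)Nc4cccc(C(F)(F)F)c4)c3)cc2-c2ccncc2)c1` is the one to be estimated. It differs from compound 2 at a single position: 3-(trifluoromethyl)phenyl in place of 3,4-dichlorophenyl on an amide-type nitrogen. The rest of the molecule stays the same.

For the measured compounds named here, no step between two measured compounds is given here, so the size of such a change is not known from measurements. Since both measured compounds sit near the top of the scale, the change from compound 2 to compound 3 is expected to produce no shift beyond the scatter, an estimated step of no change at the digits printed from compound 2 to compound 3 (within the scatter). Compound 3 is therefore expected to give about 97% in this assay, in a range from 89% to 103%.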

Compound 3, a percentage reported as activity, at one concentration (the size of the read-out at that concentration, not a potency): 100%
For compound 3 the middle estimate is 3 percentage points below the measured one, and the stated range covers the measured number.
By their numbers in this assay, from the lowest: compounds 2, 1 and 3 (each within the scatter of the next).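

In this assay, for the compounds shown here, 3-(trifluoromethyl)phenyl in place of 3,4-dichlorophenyl on the amide-type nitrogen gives a number 3 percentage points higher from compound 2 to compound 3 (within the scatter), so the first measured step at this position cannot be told from ordinary repeat-to-repeat variation. The second step, with hydrogen in place of trifluoromethyl on an aromatic carbon, gives a number 1 percentage points higher from compound 1 to compound 3 (within the scatter), so compound 3 and compound 1, which differ by one trifluoromethyl group, also cannot be told apart on this read-out. These two steps show that, at this single concentration, neither change on this aryl end produces a readable difference, although a single concentration gives no potency and cannot show how the compounds would compare at other concentrations; no supporting measurement is available to explain this result.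

The compounds shown leave open whether any group on the amide-type nitrogen would produce a readable effect at this concentration, for example a simple alkyl chain, or an aryl group carrying an amine or a carboxylic acid. They also leave open whether the three compounds would separate at higher concentrations, where one could show a stronger or weaker effect than another at each concentration tested.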